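Swapping 4-ethylcyclohexyl for iodo: a tolerance estimate

The compounds below may be only part of what the source reports. "The series", "measured", "known", "first", "only" and "open" are said of these compounds alone.

Of the compounds shown here, two have so far been tested in an ADME assay on BHK cells (Mesocricetus auratus) for cytotoxicity, read by MTT assay, with a stated time of 96 h; a lower number here means that less compound is tolerated, a higher number that more compound is tolerated. Compound 1 `O=C(NC(=S)Nc1cccc(C(F)(F)F)c1)c1ccccc1` gives > 100000 nM, which is a limit of the assay and not a number. Among the compounds with values here, compound 2 `CC[C@H]1CC[C@H](c2ccc(NC(=S)Nc3cccc(C(F)(F)F)c3)cc2)CC1` gives 10000 nM, the only true number available in this assay, so it has no measured neighbour to be ranked against.

Compound 3 `FC(F)(F)c1cccc(NC(=S)Nc2ccc(I)cc2)c1` has yet to be measured. Its difference from compound 2 is iodo in place of 4-ethylcyclohexyl on an aromatic carbon, para to a large group.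

Within the data shown here, no measured step covers this change, so any expectation is loosely anchored. The reading for compound 2 of 10000 nM is the one firm reference point. The limit seen with compound 1 leaves room above that reading. A moderate move beyond the usual scatter is therefore expected, towards more compound being tolerated, although no change at all cannot be ruled out. The estimated change is a 3.0-fold higher number from compound 2 to compound 3 (0.48 log units; beyond the scatter). For compound 3 the expected value is 30000 nM, with an estimated range from 8000 nM to 100000 nM.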

Compound 3, half-maximal cytotoxic concentration: 9400 nM
Compound 3: middle estimate off by 3.2-fold (0.50 log units), on the high side; the range from low to high includes it.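

In this assay this position gives a 1.1-fold lower number from compound 2 to compound 3 (0.03 log units; within the scatter), so iodo and 4-ethylcyclohexyl on an aromatic carbon, para to a large group, cannot be told apart by this read-out. The group that leaves has 8 heavy atoms, a six-membered non-aromatic ring and 2 defined stereocentres, while the group that enters is a single iodine atom, and this difference leaves the reading within the scatter for this pair. The compounds shown offer nothing that accounts for the agreement between these two readings.

From the compounds shown here alone, whether the same level of tolerance would hold for a wider range of groups at this position stays open, since an amine, a carboxylic acid, a methoxy group or a longer straight alkyl chain such as n-butyl could each read differently from iodo and 4-ethylcyclohexyl. Going by these compounds, it is also open whether the agreement seen here is particular to this pair of groups, or whether this position would read alike with plain hydrogen in their place.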